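Replacing 2-methylphenyl with 4-ethylphenyl on a sulfonamide nitrogen

The compounds below may be only part of what the source reports. "The series", "measured", "known", "first", "only" and "open" are said of these compounds alone.

In a functional assay on HeLa cells (Homo sapiens) for inhibition, read by CCK-8 assay, with a stated time of 72 h (on this read-out higher numbers stand for weaker inhibition and lower numbers for stronger inhibition), compound 3 `Cc1ccccc1NS(=O)(=O)c1cccc(CCCCCCNC(=O)/C=C/c2cccnc2)c1` has the lowest number of the three measured compounds at 2.34 nM, ahead of compound 2 `Cc1ccc(NS(=O)(=O)c2cccc(CCCCCCNC(=O)/C=C/c3cccnc3)c2)cc1` at 38.8 nM and compound 1 `O=C(/C=C/c1cccnc1)NCCCCc1ccc(S(=O)(=O)Nc2ccccc2)cc1` at 184 nM. In compound 4 `CCc1ccc(NS(=O)(=O)c2cccc(CCCCCCNC(=O)/C=C/c3cccnc3)c2)cc1`, 4-ethylphenyl takes the place of 2-methylphenyl on a sulfonamide nitrogen: 4-ethylphenyl in place of 2-methylphenyl on a sulfonamide nitrogen. Among the measured compounds shown here, the one measured step that bears on this is a 17-fold lower number from compound 2 to compound 3 (1.22 log units; beyond the scatter), a large step for 2-methylphenyl in place of 4-methylphenyl. For the measured compounds named here, no ethyl compound has been measured, so this evidence is thin. The expected change in this assay is a similarly large rise, estimated as a 15-fold higher number from compound 3 to compound 4 (1.17 log units; beyond the scatter). Compound 4 is expected near 35 nM, with an estimated range of 10 nM to 110 nM.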

Compound 4, half-maximal inhibitory concentration: 132 nM
Beside the measured number, compound 4's estimate is 3.8-fold (0.58 log units) below it; measured number above the stated range.
By their numbers in this assay, from the lowest: compound 3; then compound 2; then compounds 4 and 1 (each within the scatter of the next).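

With 4-ethylphenyl on the sulfonamide nitrogen, this assay gives a 56-fold higher number from compound 3 to compound 4 (1.75 log units; beyond the scatter) as a large step, so the low number of compound 3 is not shared by either of the two groups carrying a 4-alkyl chain. Lengthening that chain by one methyl gives only a 3.4-fold higher number from compound 2 to compound 4 (0.53 log units; beyond the scatter) as a modest step, far smaller than the change on leaving 2-methylphenyl. Nothing shown explains either step.

On these data alone, it remains open whether a propyl chain would raise the number further. As far as these compounds go, the effect of an amine or a carboxylic acid on this phenyl ring also remains unknown.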